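The compounds below may be only part of what the source reports. "The series", "measured", "known", "first", "only" and "open" are said of these compounds alone.

Three compounds measured in a functional assay on MCF7 cells (Homo sapiens) for antiproliferative activity, read by MTT assay, with a stated time of 72 h; a higher number here means a weaker inhibitor, a lower number a stronger inhibitor:

Compound 1 `Nc1nc(N)c2cc(CSC(=S)N3CCN(C4CCCCC4)CC3)ccc2n1` gives 6800 nM.
Compound 2 `Nc1nc(N)c2cc(CSC(=S)N3CCN(c4ccc(Cl)cc4)CC3)ccc2n1` gives 4880 nM.
Compound 3 `Nc1nc(N)c2cc(CSC(=S)N3CCN(c4ccc(C(F)(F)F)cc4)CC3)ccc2n1` gives 7400 nM.

All three share the same core and differ only in the group on an amine nitrogen in a ring. Compound 1 carries a cyclohexyl there and stands second highest of the three numbers, but its distance to the others is small: the step of a 1.4-fold lower number from compound 1 to compound 2 (0.14 log units; within the scatter) and the step of a 1.1-fold higher number from compound 1 to compound 3 (0.04 log units; within the scatter) both fall within the scatter, and so does a 1.5-fold higher number from compound 2 to compound 3 (0.18 log units; within the scatter). Among the measured compounds shown here, no compound can therefore be called stronger or weaker than another.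

Compound 4 `Nc1nc(N)c2cc(CSC(=S)N3CCN(c4ccccn4)CC3)ccc2n1` is the next step from compound 1: pyridin-2-yl in place of cyclohexyl on an amine nitrogen in a ring. For the measured compounds named here, the steps that bear on it are the two in which a six-membered aromatic ring replaced the cyclohexyl, a 1.4-fold lower number from compound 1 to compound 2 (0.14 log units; within the scatter) and a 1.1-fold higher number from compound 1 to compound 3 (0.04 log units; within the scatter), and neither moved the number beyond the scatter. Going by the values given here, a ring with one nitrogen in place of a carbon ring is a new kind of change, with no measured example, so the expectation rests on those two aryl steps alone.

On that basis the step of a 1.1-fold lower number from compound 1 to compound 4 (0.05 log units; within the scatter) is expected to stay within the scatter, in no particular direction. Compound 4 is estimated at 6000 nM, with a range from 2500 nM to 14000 nM in this assay.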

Compound 4, half-maximal inhibitory concentration: 5110 nM
The estimate for compound 4 lay 1.2-fold (0.07 log units) above the measured number, and the stated range covers the measured number.
By their numbers in this assay, from the lowest: compounds 2, 4, 1 and 3 (each within the scatter of the next).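

Swapping cyclohexyl for pyridin-2-yl brings a ring nitrogen and a hydrogen-bond acceptor to this position, yet in this assay the result is a 1.3-fold lower number from compound 1 to compound 4 (0.12 log units; within the scatter). Set against the two substituted phenyl rings, it gives a 1.4-fold lower number from compound 3 to compound 4 (0.16 log units; within the scatter) and a 1.0-fold higher number from compound 2 to compound 4 (0.02 log units; within the scatter), so the group with the hetero atom cannot be told apart from any of the three other groups at this position. The four compounds therefore show that a carbon ring, a substituted aromatic ring and an aromatic ring with a hetero atom all read alike here, but no measurement at hand offers an explanation for this.

From the compounds shown here alone, every group in this set is a six-membered ring, so it remains open whether a methyl, a longer chain or a chain ending in a carboxylic acid or an amine would move the number beyond the scatter. The shared core is also the same in all four compounds, which leaves open how much of the activity depends on it rather than on the group at this position.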